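Removing One Trifluoromethyl from a Bis-Substituted Urea

A few compounds are considered here, and "the series" means these few. Any claim that something is new, unique, unknown or untested is made for them only; others in the source may bear on it.

Compound 1 `COc1cc(Cl)cc(-c2nn(-c3cccc(NC(=O)c4ccc(Cl)c(Cl)c4)c3)cc2-c2ccncc2)c1` gives 78.5% in a functional assay on SK-MEL-5 cells (Homo sapiens) for inhibition, read by sulforhodamine B assay, with a stated time of 48 h, tested at 10 uM; a lower number here means a stronger effect, a higher number a weaker effect of the compound at the concentration tested.
Compound 2 `COc1cc(Cl)cc(-c2nn(-c3cccc(NC(=O)Nc4cc(C(F)(F)F)cc(C(F)(F)F)c4)c3)cc2-c2ccncc2)c1` gives -79.4% in this assay.

Of these two numbers compound 2 stands lowest, with compound 1 far higher, a gap beyond the usual scatter. Compound 3 `COc1cc(Cl)cc(-c2nn(-c3cccc(NC(=O)Nc4cccc(C(F)(F)F)c4)c3)cc2-c2ccncc2)c1` has not yet been tested. It differs from compound 2 by hydrogen in place of trifluoromethyl on an aromatic carbon. Going by the values given here, with only two measured compounds and no measured step of this kind, the expectation rests on the shared urea with compound 2 alone: the effect of compound 3 is expected to weaken, a step of a number 59.4 percentage points higher from compound 2 to compound 3 (beyond the scatter) in this assay. Compound 3 is therefore estimated at -20%, within a range from -75% to 50%.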

Compound 3, a percentage reported as activity, at one concentration (the size of the read-out at that concentration, not a potency): 5.3%
For compound 3 the middle estimate is 25.3 percentage points below the measured one, and the stated range covers the measured number.
By their numbers in this assay, from the lowest: compound 2; then compound 3; then compound 1.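

In this assay the second trifluoromethyl counts on its own: hydrogen in its place gives a number 84.7 percentage points higher from compound 2 to compound 3 (beyond the scatter) and so a clearly weaker effect. A single trifluoromethyl still keeps much of the effect, since (3-(trifluoromethyl)phenyl)amino in place of 3,4-dichlorophenyl on a carbonyl carbon gives a number 73.2 percentage points lower from compound 1 to compound 3 (beyond the scatter) as well. Nothing available explains why removing this group weakens the effect.

From the compounds shown here alone, whether a nitrile or an amine on that aromatic carbon would restore the effect of compound 2 remains open. So does how much of the difference from compound 1 comes from the urea itself rather than from the ring substituents.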